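Compound 3 to compound 4: hydroxy for morpholin-4-yl

The source may report more compounds than this note shows. Statements on the series, on what has been measured and on what is new or still open speak of the compounds shown alone.

The notes cover compound 1 `CNC(=O)/C=C/c1ccncc1-c1ccc2cc[nH]c2c1`, compound 2 `CCOC(=O)/C=C/c1ccncc1-c1ccc2cc[nH]c2c1`, compound 3 `O=C(/C=C/c1ccncc1-c1ccc2cc[nH]c2c1)N1CCOCC1` and the unmeasured compound 4 `O=C(O)/C=C/c1ccncc1-c1ccc2cc[nH]c2c1`, which differ only in the group on a carbonyl carbon. In a functional assay on MDA-MB-231 cells (Homo sapiens) for inhibition, read by sulforhodamine B assay, with a stated time of 72 h (on this read-out lower numbers stand for stronger inhibition of growth and higher numbers for weaker inhibition of growth), compound 1 gives 7680 nM and compound 2 gives 7980 nM.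

Compound 3 gives only a limit in this assay, > 10000 nM, and no number. It therefore stands at the limit of > 10000 nM in this assay, at which 1 of the 3 values shown sits.

The change under study is hydroxy in place of morpholin-4-yl on a carbonyl carbon. Going by the values given here, no measured step involves hydroxy, so the closest guide is the three steps among the other groups. These are a 1.0-fold higher number from compound 1 to compound 2 (0.02 log units; within the scatter), an at least 1.3-fold higher number from compound 1 to compound 3 (0.11 log units; that floor lies within the scatter) and an at least 1.2-fold higher number from compound 2 to compound 3 (0.09 log units; that floor lies within the scatter). None of them is shown to exceed the scatter, so no step beyond the scatter is expected in this assay, and no direction is favoured. The estimated step is a number no higher from compound 3 to compound 4 (the limit leaves the size open). Compound 4 is expected at 10000 nM, with an estimated range of 5000 nM to 20000 nM.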

Compound 4, concentration for 50% growth inhibition: > 10000 nM
Compound 4: a limit, no number (the forecaster's own chance of this, stated with the estimate: 50%); the middle value sits exactly at the limit.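

In this assay compound 4 gives only a limit, > 10000 nM, so hydroxy on this carbonyl carbon also yields no number, and the limit recurs: the limit of > 10000 nM in this assay, at which 2 of the 4 values shown sit. The two readable comparisons are an at least 1.2-fold higher number from compound 2 to compound 4 (0.09 log units; that floor lies within the scatter) and an at least 1.3-fold higher number from compound 1 to compound 4 (0.11 log units; that floor lies within the scatter), so neither shows a difference beyond the scatter, while the steps between the two limits cannot be read. Hydroxy, with no ring, and morpholin-4-yl, a six-membered non-aromatic ring, therefore both end at the limit, which extends the flat picture at this position to a carboxy group.

As far as these compounds go, how far compound 3 and compound 4 lie past the limit stays open. Also open, from the compounds shown here alone, is whether a primary amide, a benzylamino group or a piperazin-1-yl group on this carbonyl carbon would move growth inhibition beyond the scatter from compound 1.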